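The source may report more compounds than this note shows. Statements on the series, on what has been measured and on what is new or still open speak of the compounds shown alone.

Compound 1 `COC(=O)C1=C(C)N=C(C)/C(=C(\O)OC)C1c1ccccc1C#N`: 15.9 nM
Compound 2 `COC(=O)C1=C(C)N=C(C)/C(=C(\O)OC)C1c1cccc(C)c1`: 110 nM
Compound 3 `COC(=O)C1=C(C)N=C(C)/C(=C(\O)OC)C1c1cccc([N+](C)(C)C)c1`: 50100 nM

In a functional assay (muscle tissue) with Cavia porcellus as the target (on this read-out lower numbers stand for an effect already at smaller amounts and higher numbers for an effect only at larger amounts of compound), compound 3 has the highest number of the three, at 50100 nM. Compound 4 `COC(=O)C1=C(C)N=C(C)/C(=C(\O)OC)C1c1cccc(I)c1` differs from it by one change: one iodine atom in place of a group of 4 heavy atoms (3 carbon, 1 nitrogen; no ring), on an aromatic carbon. The group that leaves has a net charge of +1, while the iodo that enters has no net charge. The closest evidence is a 460-fold higher number from compound 2 to compound 3 (2.66 log units; beyond the scatter), a large step that swapped a single carbon atom for the same charged group. Going by the values given here, the change here runs the opposite way, though no iodo compound has been measured. The modest 6.9-fold higher number from compound 1 to compound 2 (0.84 log units; beyond the scatter) involves a different change and shows only how far compounds lacking that group can lie apart. A large fall is therefore expected, to near compound 2. The expected change is a 500-fold lower number from compound 3 to compound 4 (2.70 log units; beyond the scatter). For compound 4 the estimated value is 100 nM, with an expected range from 25 nM to 400 nM.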

Compound 4, half-maximal effective concentration: 41.7 nM
For compound 4 the middle estimate is 2.4-fold (0.38 log units) above the measured one; the measured number falls inside the stated range.
By their numbers in this assay, from the lowest: compound 1; then compound 4; then compound 2; then compound 3.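

Putting iodo in place of the group with a net charge of +1 gives a 1200-fold lower number from compound 3 to compound 4 (3.08 log units; beyond the scatter) in this assay and shows that this aromatic carbon can carry a single large atom without loss. Iodo even improves on methyl here, with a 2.6-fold lower number from compound 2 to compound 4 (0.42 log units; beyond the scatter) as the step beyond the scatter. The gap of a 2.6-fold higher number from compound 1 to compound 4 (0.42 log units; beyond the scatter) remains, but that step swaps the whole substituted phenyl group, and nothing available explains any of these differences.

From the compounds shown here alone, how an amine, a carboxylic acid or a longer alkyl chain would fare on this same carbon stays open.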